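This account rests on a few compounds, and the source may have more. Where it says the series, first, only, none or still open, it means among the compounds named here.

In a functional assay on HCC1806 cells (Homo sapiens) for inhibition, read by sulforhodamine B assay, tested at 10 uM (on this read-out lower numbers stand for less inhibition and higher numbers for more inhibition at the one concentration tested (going by the name of the read-out)), three compounds of one shared core have been measured. Compound 1 `COC(=O)CC(=O)N1N=C(c2ccc(N3CCN(C)CC3)cc2)CC1c1ccc(N(C)C)cc1` gives -8.3%; compound 2 `CN1CCN(c2ccc(C3=NN(C(=O)c4ccc(C(F)(F)F)cc4)C(c4ccc(N(C)C)cc4)C3)cc2)CC1` gives 84.1%; compound 3 `CN1CCN(c2ccc(C3=NN(S(=O)(=O)C4CC4)C(c4ccc(N(C)C)cc4)C3)cc2)CC1` gives 4.7%. Compound 3 thus stands second highest of the three, with a number 13 percentage points higher from compound 1 to compound 3 (beyond the scatter) and a number 79.4 percentage points lower from compound 2 to compound 3 (beyond the scatter). Compound 4 `Cc1ccc(S(=O)(=O)N2N=C(c3ccc(N4CCN(C)CC4)cc3)CC2c2ccc(N(C)C)cc2)cc1` differs from compound 3 in one place: 4-methylphenyl in place of cyclopropyl on a sulfonyl sulfur. Among the measured compounds shown here, no measured step changes the group on the sulfonyl sulfur, so the steps seen so far bear on it only loosely; they show that changing the group on the ring nitrogen moves this read-out by large amounts in either direction. A modest rise is expected for compound 4, a number 30.3 percentage points higher from compound 3 to compound 4 (beyond the scatter), with wide uncertainty. The estimate for compound 4 is 35%, between 0% and 75%.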

Compound 4, a percentage reported as inhibition, at one concentration (the size of the read-out at that concentration, not a potency): 32.2%
Beside the measured number, compound 4's estimate is 2.8 percentage points above it; measured number inside the range.
By their numbers in this assay, from the lowest: compound 1; then compound 3; then compound 4; then compound 2.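

Among the compounds shown here, this is the first step that changes the group on the sulfonyl sulfur while the sulfonyl itself stays: in this assay, 4-methylphenyl in place of cyclopropyl gives a clear gain (a number 27.5 percentage points higher from compound 3 to compound 4 (beyond the scatter)). Even so, (4-methylphenyl)sulfonyl on the ring nitrogen does not match the (4-(trifluoromethyl)phenyl)carbonyl group (a number 51.9 percentage points lower from compound 2 to compound 4 (beyond the scatter)), though it clearly beats the ((methoxycarbonyl)methyl)carbonyl group (a number 40.5 percentage points higher from compound 1 to compound 4 (beyond the scatter)). Nothing measured here explains these differences. From the compounds shown here alone, how a longer carbon chain or an amine on the sulfonyl sulfur would compare remains open.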